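Fluoro to hydrogen: expected growth inhibition of compound 3

The source may report more compounds than this note shows. Statements on the series, on what has been measured and on what is new or still open speak of the compounds shown alone.

Measured so far:
- compound 1, `N#Cc1ccc(-c2cnc3[nH]cc(-c4nnc(-c5ccc(Cl)cc5)o4)c(=O)c3c2)cc1`: 19.7%
- compound 2, `CS(=O)(=O)c1ccc(-c2cnc3[nH]cc(-c4nnc(-c5ccc(F)cc5)o4)c(=O)c3c2)cc1`: 8.1%

In a functional assay on MCF7 cells (Homo sapiens) for inhibition, read by MTT assay, with a stated time of 24 h, tested at 10 uM (on this read-out lower numbers stand for less inhibition of growth and higher numbers for more inhibition of growth at the one concentration tested), compound 1 gives 19.7%, and compound 2 gives 8.1%. Compound 2 stands lowest of the two numbers; its nearest neighbour is compound 1, whose number is higher by a margin beyond the scatter. For the measured compounds named here, compound 1 and compound 2 differ from each other in more than one place, so no single step between them is counted, and only what their two values show can be stated.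

Compound 3, `CS(=O)(=O)c1ccc(-c2cnc3[nH]cc(-c4nnc(-c5ccccc5)o4)c(=O)c3c2)cc1`, has not yet been measured. It differs from compound 2 as follows: hydrogen in place of fluoro on an aromatic carbon. Nothing else in the structure changes. Going by the values given here, no step between measured compounds exists for this kind of change, so the expectation rests on compound 2 alone. The expected step of a number 1.1 percentage points lower from compound 2 to compound 3 (within the scatter) is small, none beyond the scatter, with the number for compound 3 estimated near that of compound 2. Compound 3 is expected to give about 7%, within an estimated range from 0% to 18%.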

Compound 3, percent growth inhibition at one concentration: 2.83%
Beside the measured number, compound 3's estimate is 4.2 percentage points above it, and the stated range covers the measured number.
By their numbers in this assay, from the lowest: compounds 3 and 2 (each within the scatter of the next); then compound 1.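

In this assay, for the compounds shown here, the change from 4-fluorophenyl to phenyl, with hydrogen in place of fluoro on an aromatic carbon para to a large group, gives a number 5.3 percentage points lower from compound 2 to compound 3 (within the scatter) and supplies the first step that can be read at a single place. At this position, removing the fluoro while leaving the rest of the structure unchanged therefore does not move the number beyond the scatter, so this one step gives no sign that the fluoro matters for growth inhibition at the one concentration tested. No measurement bearing on the reason for this result is available.

From the compounds shown here alone, whether any other group on this aromatic carbon can move the number beyond the scatter remains open, and an amine, a carboxylic acid or a methoxy group there would each give a one-place comparison with compound 3. Going by these compounds, compound 1 carries a chloro on this ring and a nitrile at the far end of the molecule, so the separate contribution of each place to its number remains open as well.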